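The compounds below may be only part of what the source reports. "The series", "measured", "known", "first", "only" and "open" are said of these compounds alone.

Working notes on the series in a functional assay on HCT-8 cells (Homo sapiens) for antiproliferative activity, read by MTT assay, with a stated time of 72 h; a lower number here means a stronger inhibitor, a higher number a weaker inhibitor. Of the compounds shown here, three have measured numbers so far. Compound 1 `COc1ccc(O)c(/C=C/C(=O)c2ccc(Cl)cc2)c1` gives 19700 nM in this assay. Compound 2 `O=C(/C=C/c1cc(F)ccc1O)c1ccc(Cl)cc1` gives 25600 nM. Compound 3 `COc1ccc(OC(=O)c2ccccc2OC(C)=O)c(/C=C/C(=O)c2ccc(Cl)cc2)c1` gives 2400 nM, the lowest of the three numbers; the gap to compound 1 and the gap to compound 2 both lie beyond the scatter, so compound 3 is the strongest inhibitor measured here.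

Within the data shown here, the one single-site step among the measured compounds runs a 1.3-fold higher number from compound 1 to compound 2 (0.11 log units; within the scatter), so exchanging methoxy for fluoro on the free-hydroxyl core left the number essentially unchanged.

Compound 4 `CC(=O)Oc1ccccc1C(=O)Oc1ccc(F)cc1/C=C/C(=O)c1ccc(Cl)cc1` is the next compound, not yet measured. It differs from compound 3 by fluoro in place of methoxy on an aromatic carbon. This is the same exchange as the step from compound 1 to compound 2, now carried out on the core that bears the acetylsalicyloyl ester instead of the free hydroxyl. Among the measured compounds shown here, only that one step bears on the question, and it was within the scatter. The step is therefore expected to be a 1.2-fold higher number from compound 3 to compound 4 (0.08 log units; within the scatter), that is, no change beyond the scatter, with a slight lean toward a higher number because the step from compound 1 to compound 2 was a 1.3-fold higher number from compound 1 to compound 2 (0.11 log units; within the scatter). Compound 4 is expected at 2900 nM, with a range from 1400 nM to 6000 nM.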

Compound 4, half-maximal inhibitory concentration: 2700 nM
Beside the measured number, compound 4's estimate is 1.1-fold (0.03 log units) above it, and the stated range covers the measured number.
By their numbers in this assay, from the lowest: compounds 3 and 4 (each within the scatter of the next); then compounds 1 and 2 (each within the scatter of the next).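

In this assay, fluoro in place of methoxy on the core bearing the acetylsalicyloyl ester gives a 1.1-fold higher number from compound 3 to compound 4 (0.05 log units; within the scatter), so the earlier result at this position, meta to a large group and para to a large group, is not confined to the free-hydroxyl core. The exchange can now be read on two cores, and the two readings agree: the same change on two cores in this assay, a 1.3-fold higher number (0.11 log units; within the scatter) from compound 1 to compound 2 and a 1.1-fold higher number (0.05 log units; within the scatter) from compound 3 to compound 4, 1.2-fold (0.06 log units) apart, within the scatter of two such steps. The printed values also show that the lower number of the ester-bearing core holds with either group: with fluoro, compound 2 gives 25600 nM and compound 4 gives 2700 nM, the same direction as with methoxy, where compound 1 gives 19700 nM and compound 3 gives 2400 nM.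

Methoxy and fluoro are the only groups compared at this position, so it remains open whether an amine, a carboxylic acid or a trifluoromethyl group would also leave the number within the scatter on either core. From the compounds shown here alone, it also remains open whether the whole acetylsalicyloyl ester is needed for the lower number, or whether a simple acetate ester on the same oxygen would give a similar value.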